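The source may report more compounds than this note shows. Statements on the series, on what has been measured and on what is new or still open speak of the compounds shown alone.

In an ADME assay on HEK293 cells (Homo sapiens) for cytotoxicity, read by CCK-8 assay, with a stated time of 48 h (on this read-out lower numbers stand for stronger inhibition and higher numbers for weaker inhibition), compound 1 (`COc1ccc(/C=C\c2cc(OC)c(OC)c(OC)c2)cc1OCc1ccc(CO)cc1`) gives 37000 nM. Compound 2 (`COc1ccc(/C=C\c2cc(OC)c(OC)c(OC)c2)cc1OCc1ccc(CN2CC(C(=O)O)C2)cc1`) gives > 50000 nM, which is a limit of the assay and not a number. Compound 3 (`COc1ccc(/C=C\c2cc(OC)c(OC)c(OC)c2)cc1OCc1ccc(CNCCN(C)C)cc1`) carries (2-(dimethylamino)ethyl)amino in place of the 3-carboxyazetidin-1-yl of compound 2, on a saturated chain carbon bound to an aromatic carbon: (2-(dimethylamino)ethyl)amino in place of 3-carboxyazetidin-1-yl on a saturated chain carbon bound to an aromatic carbon. For the measured compounds named here, only one measured step bears on this place, an at least 1.3-fold higher number from compound 1 to compound 2 (0.13 log units; that floor lies within the scatter), and it gives no size beyond the scatter. On these data alone, no clear step is therefore expected in this assay, and the direction stays open. The expected change is an at least 1.4-fold lower number from compound 2 to compound 3 (0.15 log units; that floor lies within the scatter). Compound 3 is estimated at 35000 nM, with an expected range of 12000 nM to 60000 nM.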

Compound 3, half-maximal inhibitory concentration: 39000 nM
Estimate against measurement, compound 3: 1.1-fold (0.05 log units) below; the range from low to high includes it.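

For the compounds shown here, at this place, on a saturated chain carbon bound to an aromatic carbon, (2-(dimethylamino)ethyl)amino in place of hydroxy gives a 1.1-fold higher number from compound 1 to compound 3 (0.02 log units; within the scatter) in this assay, the first comparison here with a measured number at both ends, and it shows no change beyond the scatter. Leaving 3-carboxyazetidin-1-yl for (2-(dimethylamino)ethyl)amino gives an at least 1.2-fold lower number from compound 2 to compound 3 (0.10 log units; that floor lies within the scatter), which is only a floor. Compound 2 stands at a limit of the assay, not at a number: the limit of > 50000 nM in this assay, at which 1 of the 3 values shown sits.

On these data alone, how far compound 2 truly lies from the other two stays open. As far as these compounds go, whether a primary amine or a longer chain at this place would give a step beyond the scatter also stays open.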